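The compounds below may be only part of what the source reports. "The series", "measured", "known", "first", "only" and "open" are said of these compounds alone.

Measured compounds in the series:

compound 1, `CCCc1cn(C(c2ccccc2)c2ccccc2)nn1` — 11000 nM
compound 2, `c1ccc(Cn2nccn2)cc1` — 16300 nM
compound 3, `c1ccc(C(c2ccccc2)n2nccn2)cc1` — 12000 nM

All three numbers come from an assay on isolated protein for inhibition of Aromatase (Homo sapiens), read by fluorescence and colorimetric assay, with a stated time of 30 min; on this read-out higher numbers stand for weaker inhibition and lower numbers for stronger inhibition. In this assay compound 1 gives 11000 nM and compound 3 gives 12000 nM, and these two values lie within the scatter of each other. Compound 2 gives 16300 nM in this assay, and its step from compound 3 is also within the scatter.

For the measured compounds named here, the pair compound 3 and compound 2 is the one measured example of a single change, (hydrogen in place of phenyl on a saturated chain carbon bound to an aromatic carbon and an aromatic nitrogen), which made the step of a 1.4-fold higher number from compound 3 to compound 2 (0.13 log units; within the scatter). Compound 1 and compound 3 differ in more than one place, and the difference between the two cores is not broken down here.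

Compound 4, `CCCc1cn(Cc2ccccc2)nn1`, is not yet measured in this assay. It differs from compound 1 by hydrogen in place of phenyl on a saturated chain carbon bound to an aromatic carbon and an aromatic nitrogen. Going by the values given here, the place of this change, as described for both pairs, is the same word for word, so it is the same change as the one from compound 3 to compound 2, carried out on the core of compound 1.

Among the compounds with values here, for compound 4 the expected step is a 1.4-fold higher number from compound 1 to compound 4 (0.13 log units; within the scatter), resting on the measured step of a 1.4-fold higher number from compound 3 to compound 2 (0.13 log units; within the scatter), since no other measured pair bears on this change. The estimate for compound 4 in this assay is 15000 nM, with an expected range from 7000 nM to 35000 nM.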

Compound 4, half-maximal inhibitory concentration: 12600 nM
Beside the measured number, compound 4's estimate is 1.2-fold (0.08 log units) above it; low and high end bracket the measured number.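

In this assay, the change of phenyl to hydrogen on a saturated chain carbon bound to an aromatic carbon and an aromatic nitrogen now has a second reading, a 1.1-fold higher number from compound 1 to compound 4 (0.06 log units; within the scatter). Set beside the earlier reading on the other core, the two steps do not differ: the same change on two cores in this assay, a 1.4-fold higher number (0.13 log units; within the scatter) from compound 3 to compound 2 and a 1.1-fold higher number (0.06 log units; within the scatter) from compound 1 to compound 4, 1.2-fold (0.07 log units) apart, within the scatter of two such steps

This shows that, on these two cores, the change leaves the number within the scatter each time, but it does not show that a step of real size would carry over from one core to the other, and two cores make no rule for the wider series.

Still open, on these data alone, is whether a methyl or an amine in place of phenyl at that same carbon, or a longer chain on the core of compound 1, would shift the number beyond the scatter. The four compounds shown are read in this assay alone, which leaves open how this change behaves on any other read-out.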